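Substituent swap on a pyrazoline anti-inflammatory series

The source may report more compounds than this note shows. Statements on the series, on what has been measured and on what is new or still open speak of the compounds shown alone.

Measured so far:
- compound 1, `NS(=O)(=O)c1ccc2nc(N3N=C(c4ccc(Cl)cc4)CC3c3ccccc3)sc2c1`: 68.3%
- compound 2, `COc1ccc(C2CC(c3ccc(Br)cc3)=NN2c2nc3ccc(S(N)(=O)=O)cc3s2)cc1`: 14%
- compound 3, `Cc1ccc(C2CC(c3ccc(Cl)cc3)=NN2c2nc3ccc(S(N)(=O)=O)cc3s2)cc1`: 14%

In a functional assay on the whole organism (strain Wistar) for inhibition, with Rattus norvegicus as the target, read by paw edema, with stated times of 1 h and 5 h, at a dose of 20 mg/kg by the oral route (a lower number here means less inhibition, a higher number more inhibition at the dose given (going by the name of the read-out)), compound 1 stands clearly at the top of the three. Compound 3 gives 14%, level with compound 2 at the digits shown; the two sit together at the bottom, and the gap between them is within the scatter. Going by the values given here, the single change from compound 1 to compound 3, methyl in place of hydrogen on an aromatic carbon, brings a number 54.3 percentage points lower from compound 1 to compound 3 (beyond the scatter), a large fall.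

The next compound, compound 4, `COc1ccc(C2CC(c3ccc(Cl)cc3)=NN2c2nc3ccc(S(N)(=O)=O)cc3s2)cc1`, is compound 3 with methoxy in place of methyl on an aromatic carbon. Among the compounds with values here, no measured pair shows exactly this exchange, so the step from compound 1 to compound 3 is the only measured step at that position, and it tells only that adding a group there cut inhibition sharply. Compound 2, which already carries the methoxy group with a different halogen on the other aromatic ring, gives 14%, the same low level as compound 3. Taken together these point to no change beyond the scatter.

Compound 4 is therefore expected to show a step of a number 1 percentage points higher from compound 3 to compound 4 (within the scatter), an estimated 15% with a range from 5% to 30%.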

Compound 4, a percentage reported as inhibition, in the whole organism at one dose (the size of the read-out at that dose, not a potency): 67.7%
Compound 4: the middle estimate sits 52.7 percentage points below what was measured; measured number above the stated range.
By their numbers in this assay, from the lowest: compounds 2 and 3 (each within the scatter of the next); then compounds 4 and 1 (each within the scatter of the next).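

In this assay, the swap from 4-methylphenyl to 4-methoxyphenyl brings a number 53.7 percentage points higher from compound 3 to compound 4 (beyond the scatter) and shows that this place does not lose inhibition whenever any group is added: the outcome depends on which group sits there. Against hydrogen at the same carbon, methoxy brings a number 0.6 percentage points lower from compound 1 to compound 4 (within the scatter) while methyl brought a number 54.3 percentage points lower from compound 1 to compound 3 (beyond the scatter) and so the sharp loss seen earlier belongs to methyl, not to substitution as such. The halogen on the other aromatic ring also counts, since chloro in place of bromo brings a number 53.7 percentage points higher from compound 2 to compound 4 (beyond the scatter) and the low number of compound 2 therefore says nothing against methoxy on its own.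

Nothing available here bears on why one added oxygen atom or one halogen exchange should produce steps this large. Open too, as far as these compounds go, is where an ethoxy group, a hydroxyl, an amine or a carboxylic acid would fall at this place, and whether bromo paired with hydrogen or methyl on the other ring would follow the same course as chloro.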